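From 4-vinylphenyl to 3-amino-4-methoxyphenyl on the shared core

This account rests on a few compounds, and the source may have more. Where it says the series, first, only, none or still open, it means among the compounds named here.

In a functional assay on MCF7 cells (Homo sapiens) for inhibition, read by CCK-8 assay, with a stated time of 48 h (a lower number here means a stronger inhibitor, a higher number a weaker inhibitor), compound 1 `COc1cc(-c2ccnc3cc(-c4c[nH]c5ccccc45)nn23)cc(OC)c1OC` gives 85 nM, compound 2 `COc1cc(-c2ccnc3cc(-c4ccc(N(C)C)cc4)nn23)cc(OC)c1OC` gives 44 nM and compound 3 `C=Cc1ccc(-c2cc3nccc(-c4cc(OC)c(OC)c(OC)c4)n3n2)cc1` gives 193 nM, the highest number of the three and so the weakest inhibitor in the set. Compound 4 `COc1ccc(-c2cc3nccc(-c4cc(OC)c(OC)c(OC)c4)n3n2)cc1N` is still unmeasured. It carries 3-amino-4-methoxyphenyl in place of 4-vinylphenyl on an aromatic carbon of the shared core (3-amino-4-methoxyphenyl in place of 4-vinylphenyl on an aromatic carbon).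

Two measured steps arrive at the 4-vinylphenyl group: a 2.3-fold higher number from compound 1 to compound 3 (0.36 log units; beyond the scatter), and a 4.4-fold higher number from compound 2 to compound 3 (0.64 log units; beyond the scatter). The third step, a 1.9-fold lower number from compound 1 to compound 2 (0.29 log units; within the scatter), stays within the scatter. Going by the values given here, compound 4 leaves that same group, so it runs the opposite way to those two steps, although no measured compound carries its new group. A modest move to a lower number therefore seems likelier than none, with real uncertainty. The expected change is a 3.5-fold lower number from compound 3 to compound 4 (0.55 log units; beyond the scatter). The estimate for compound 4 is 55 nM, within an expected range of 15 nM to 170 nM.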

Compound 4, half-maximal inhibitory concentration: 27 nM
Compound 4: middle estimate off by 2.0-fold (0.31 log units), on the high side; low and high end bracket the measured number.
By their numbers in this assay, from the lowest: compounds 4, 2 and 1 (each within the scatter of the next, the first and the last beyond it); then compound 3.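

In this assay, 3-amino-4-methoxyphenyl gives the widest step yet seen at this position (a 7.1-fold lower number from compound 3 to compound 4 (0.85 log units; beyond the scatter)). It also separates from the indole group (a 3.1-fold lower number from compound 1 to compound 4 (0.50 log units; beyond the scatter)), which 4-(dimethylamino)phenyl did not do, yet it cannot be told apart from 4-(dimethylamino)phenyl itself (a 1.6-fold lower number from compound 2 to compound 4 (0.21 log units; within the scatter)), so two differently substituted phenyl groups now read alike here and both read clearly better than 4-vinylphenyl. Nothing in the data shown explains these differences.

The compounds shown leave open what the amino and methoxy groups each contribute, as none of them carries either group alone on this phenyl ring. Also open, from the compounds shown here alone, is how a hydroxyl group or an acetamide in place of the amino group would read in this assay.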